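This account rests on a few compounds, and the source may have more. Where it says the series, first, only, none or still open, it means among the compounds named here.

Two compounds share one core and differ only in the small aromatic ring that sits on a saturated chain carbon bound to an aromatic carbon and a saturated chain carbon. Compound 1 `Cn1ccnc1C(CC(=O)O)c1ccc(OCC2COc3ccc(Cl)cc3O2)cc1` carries a 1-methyl-1H-imidazol-2-yl group there; in a functional assay on HEK293 cells for agonist activity at Free fatty acid receptor 1 (Homo sapiens), read by fluorescence and calcium flux, with a stated time of 10 min (a lower number here means that less compound is needed, a higher number that more compound is needed for the effect), compound 1 gives 5880 nM. Compound 2 `Cn1nncc1C(CC(=O)O)c1ccc(OCC2COc3ccc(Cl)cc3O2)cc1` carries a 1-methyl-1H-1,2,3-triazol-5-yl group instead, and in this assay compound 2 gives 3870 nM. Among the compounds with values here, the step of a 1.5-fold lower number from compound 1 to compound 2 (0.18 log units; within the scatter) is the only measured step, and it lies within the scatter, so compound 2 has the lowest of the two numbers without being separated from compound 1 in any reliable way.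

Compound 3 `O=C(O)CC(c1ccncc1)c1ccc(OCC2COc3ccc(Cl)cc3O2)cc1` is the next change: pyridin-4-yl in place of 1-methyl-1H-1,2,3-triazol-5-yl on a saturated chain carbon bound to an aromatic carbon and a saturated chain carbon. Within the data shown here, the one measured step that bears on this, the ring swap from compound 1 to compound 2, was small, which gives little ground to expect a step beyond the scatter here. The number for compound 3 in this assay is therefore estimated at 3800 nM, with a range from 1300 nM to 11000 nM. This estimate means a step of a 1.0-fold lower number from compound 2 to compound 3 (0.01 log units; within the scatter) from compound 2 to compound 3, which is expected to stay within the scatter.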

Compound 3, half-maximal effective concentration: 1170 nM
Beside the measured number, compound 3's estimate is 3.2-fold (0.51 log units) above it; measured number below the stated range.
By their numbers in this assay, from the lowest: compound 3; then compounds 2 and 1 (each within the scatter of the next).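

At the position on a saturated chain carbon bound to an aromatic carbon and a saturated chain carbon, the choice of ring now makes a measurable difference in this assay: pyridin-4-yl gives a 3.3-fold lower number from compound 2 to compound 3 (0.52 log units; beyond the scatter) and a 5.0-fold lower number from compound 1 to compound 3 (0.70 log units; beyond the scatter), whereas 1-methyl-1H-imidazol-2-yl and 1-methyl-1H-1,2,3-triazol-5-yl could not be told apart. Both steps are modest, but they show that this position responds to the identity of the ring, even though 1-methyl-1H-1,2,3-triazol-5-yl and pyridin-4-yl both have 6 heavy atoms and differ instead in ring size, in the number of nitrogen atoms and in hydrogen-bond acceptors. Nothing measured on these compounds explains why the number falls with this swap.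

The compounds shown cannot separate the effect of ring size from that of the number or placement of ring nitrogen atoms, since these features change together in the step to pyridin-4-yl. As far as these compounds go, a plain phenyl ring, with no ring nitrogen, and the isomeric pyridin-3-yl and pyridin-2-yl groups would be the direct comparisons for compound 3, and how they would fall remains open.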